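This account rests on a few compounds, and the source may have more. Where it says the series, first, only, none or still open, it means among the compounds named here.

Working notes on the series. Of the compounds shown here, two have numbers so far in a functional assay on A-431 cells (Homo sapiens) for antiproliferative activity, read by MTT assay, with a stated time of 72 h; a lower number here means a stronger inhibitor, a higher number a weaker inhibitor. Compound 1 `COc1cc2ncnc(Nc3cccc(Cl)c3)c2cc1OCCCCC(=O)Nc1ccc(S(N)(=O)=O)cc1` gives 30400 nM in this assay. Compound 2 `C#Cc1cccc(Nc2ncnc3ccc(NC(=S)Nc4ccc(S(N)(=O)=O)cc4)cc23)c1` gives 15300 nM in this assay. Among the measured compounds shown here, the two numbers lie within the scatter of each other, so no order between compound 1 and compound 2 can be read from them; compound 2 is merely the one whose number is not the higher of the two.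

Compound 3 `NS(=O)(=O)c1ccc(NC(=S)Nc2ccc3ncnc(Nc4cccc(Br)c4)c3c2)cc1` is not yet measured. It differs from compound 2 in one place: bromo in place of ethynyl on an aromatic carbon. For the measured compounds named here, no measured pair shows this exchange, so no step size is known for it. The expectation is a change no larger than the scatter, in either direction, so the step from compound 2 to compound 3 is estimated at a 1.0-fold higher number from compound 2 to compound 3 (0.02 log units; within the scatter). Compound 3 is therefore expected to give about 16000 nM in this assay, within a range from 5000 nM to 50000 nM.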

Compound 3, half-maximal inhibitory concentration: 20700 nM
The estimate for compound 3 lay 1.3-fold (0.11 log units) below the measured number; low and high end bracket the measured number.
By their numbers in this assay, from the lowest: compounds 2, 3 and 1 (each within the scatter of the next).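

Among the compounds shown here, this is the first exchange that can be read as a step: in this assay, bromo in place of ethynyl, on an aromatic carbon meta to a large group, gives a 1.4-fold higher number from compound 2 to compound 3 (0.13 log units; within the scatter) with the rest of the structure unchanged. At this position, 3-ethynylphenyl and 3-bromophenyl therefore cannot be told apart in this assay, although the exchange replaces a group with a triple bond by a single bromine atom. No measurement shown bears on why the two groups read alike.

As far as these compounds go, it remains open whether any group at this position can move the number beyond the scatter, for example an amine, a nitrile or a carboxylic acid in place of bromo. From the compounds shown here alone, it is also open whether bromo and ethynyl read alike on the core of compound 1.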